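Replacing the 3-nitrophenyl group of compound 1: working notes

This account rests on a few compounds, and the source may have more. Where it says the series, first, only, none or still open, it means among the compounds named here.

For the measured compounds named here, only two compounds have measured numbers so far. In a functional assay on HeLa cells (Homo sapiens) for cytotoxicity, read by MTT assay, with a stated time of 48 h (a lower number here means a stronger inhibitor, a higher number a weaker inhibitor), compound 1 `C=C1CCC[C@]2(C)CCC(c3cn(-c4cccc([N+](=O)[O-])c4)nn3)=CC[C@@]12C` gives 31900 nM, the lower of the two numbers and so the stronger result. In this assay compound 2 `C=C1CCC[C@]2(C)CCC(c3cn(CC(=O)Nc4ccc(C)cc4)nn3)=CC[C@@]12C` gives 131000 nM, and the gap between the two lies beyond the usual scatter.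

The next compound is compound 3 `C=C1CCC[C@]2(C)CCC(c3cn(-c4ccc(Cl)cc4)nn3)=CC[C@@]12C`, which has not yet been measured. It carries 4-chlorophenyl in place of 3-nitrophenyl on an aromatic nitrogen, while the shared core stays the same. Going by the values given here, no measured pair isolates this change, so neither its size nor its direction can be read from the data. Each group holds one six-membered aromatic ring of carbon only. With compound 1 at 31900 nM as the sole close anchor, no shift beyond the scatter is expected in this assay, and no firm direction is assumed. The expected change is a 1.0-fold higher number from compound 1 to compound 3 (0.00 log units; within the scatter). For compound 3 the estimated value is 32000 nM, with an expected range of 14000 nM to 80000 nM.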

Compound 3, half-maximal inhibitory concentration: 18800 nM
For compound 3 the middle estimate is 1.7-fold (0.23 log units) above the measured one; low and high end bracket the measured number.
By their numbers in this assay, from the lowest: compounds 3 and 1 (each within the scatter of the next); then compound 2.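

For the compounds shown here, the first step that changes one place, 4-chlorophenyl in place of 3-nitrophenyl on the aromatic nitrogen, reads in this assay as a 1.7-fold lower number from compound 1 to compound 3 (0.23 log units; within the scatter) and so gives this position its first direct reading. The group that leaves carries 2 hydrogen-bond acceptors and the group that enters carries 0, yet the two numbers stay within the scatter of each other, so in this one pair the acceptors of the 3-nitrophenyl group are not required for a number at this level. No measured data on hand account for this outcome.

The exchange alters both the group on the phenyl ring and its ring position, so 3-nitrophenyl and 4-chlorophenyl alone cannot show which of the two matters, and 3-chlorophenyl or 4-nitrophenyl would be needed to separate them. Also open, as far as these compounds go, is whether unsubstituted phenyl, or a phenyl ring bearing an amine or a carboxylic acid, would shift the number beyond the scatter at this position.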